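The compounds below may be only part of what the source reports. "The series", "measured", "known", "first", "only" and "open" are said of these compounds alone.

In a functional assay on cells (Endothelial cell, Bos taurus) for antiproliferative activity (a higher number here means a weaker inhibitor, a lower number a stronger inhibitor), compound 1 (`COc1ccc(/C=C(/F)c2cc(OC)c(OC)c(OC)c2)cc1O`) gives 1700 nM as the lowest number measured; compound 2 (`COc1ccc(/C=C(\F)c2cc(OC)c(OC)c(OC)c2)cc1O`) gives 13000 nM and compound 3 (`COc1ccc(/C(F)=C/c2cc(OC)c(OC)c(OC)c2)cc1N`) gives 111000 nM on the same read-out. Compound 4 (`COc1ccc(/C=C(/F)c2cc(OC)c(OC)c(OC)c2)cc1[N+](=O)[O-]`) keeps the core of compound 1 and has nitro in place of hydroxy on an aromatic carbon. Among the measured compounds shown here, the only measured step (a 7.6-fold higher number from compound 1 to compound 2 (0.88 log units; beyond the scatter)) goes with the fact that compounds 1 and 2 differ only in the configuration as drawn and leaves that group untouched, so it serves only as a gauge of size. Differing from compound 1 in more than one place, compound 3 also lacks the hydroxy and stands at 111000 nM as a pointer upward. A rise of about that gauge's size is therefore expected in this assay (an 8.2-fold higher number from compound 1 to compound 4 (0.92 log units; beyond the scatter)). Compound 4 is estimated at 14000 nM (range 3500 nM to 60000 nM).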

Compound 4, half-maximal inhibitory concentration: 38400 nM
Estimate against measurement, compound 4: 2.7-fold (0.44 log units) below; the range from low to high includes it.
By their numbers in this assay, from the lowest: compound 1; then compound 2; then compound 4; then compound 3.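

At this place, on an aromatic carbon ortho to a methoxy group, nitro in place of hydroxy gives a 23-fold higher number from compound 1 to compound 4 (1.35 log units; beyond the scatter) in this assay. The position is therefore not indifferent to its substituent: with the double bond drawn as in compound 1, this single replacement is enough for a large rise. Nothing at hand accounts for the size of that rise.

Going by these compounds, whether the rise follows the loss of hydroxy or the entry of nitro stays open. A carboxylic acid or an acetamide on this carbon, with the rest of compound 1 unchanged, would help separate the two.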